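A few compounds are considered here, and "the series" means these few. Any claim that something is new, unique, unknown or untested is made for them only; others in the source may bear on it.

The series shares one core; what varies is the aryl group carried on the amide-type nitrogen. Compound 1 `CCc1cccc(NC(=O)CSc2nc(Nc3ccccc3)c3ccccc3n2)c1` gives 12400 nM in a functional assay on MDA-MB-231 cells (Homo sapiens) for inhibition, read by MTT assay, with a stated time of 72 h; on this read-out lower numbers stand for stronger inhibition and higher numbers for weaker inhibition. Compound 2 `O=C(CSc1nc(Nc2ccccc2)c2ccccc2n1)Nc1ccc(C(F)(F)F)cc1` gives 11100 nM in this assay. The step of a 1.1-fold lower number from compound 1 to compound 2 (0.05 log units; within the scatter) exchanges the aryl on that nitrogen and stays within the scatter, so compound 2 is not separated from compound 1 on the numbers in hand, and the pair gives no direction at all.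

Compound 3 `O=C(CSc1nc(Nc2ccccc2)c2ccccc2n1)Nc1ccc(Cl)c(Cl)c1` carries a further exchange at the same place: 3,4-dichlorophenyl in place of 4-(trifluoromethyl)phenyl on an amide-type nitrogen. Within the data shown here, the only measured step that bears on it is a 1.1-fold lower number from compound 1 to compound 2 (0.05 log units; within the scatter), an exchange of one aryl for another on the same nitrogen, and it moved the number by an amount within the scatter. Nothing measured distinguishes a halogenated aryl from any other at this position. On that basis no step beyond the scatter is expected in this assay, in either direction. The step expected is a 1.1-fold lower number from compound 2 to compound 3 (0.02 log units; within the scatter). Compound 3 is estimated at 10500 nM, with a range from 4000 nM to 28000 nM.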

Compound 3, half-maximal inhibitory concentration: 14500 nM
Beside the measured number, compound 3's estimate is 1.4-fold (0.14 log units) below it; measured number inside the range.
By their numbers in this assay, from the lowest: compounds 2, 1 and 3 (each within the scatter of the next).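

With a third aryl on the amide-type nitrogen the picture stays flat: the exchange gives a 1.3-fold higher number from compound 2 to compound 3 (0.12 log units; within the scatter) and, read against the other aryl, a 1.2-fold higher number from compound 1 to compound 3 (0.07 log units; within the scatter) in this assay and so does not separate 3,4-dichlorophenyl from either earlier group. The pair of compounds 1 and 2 rested on a single step, whereas all three aryl groups, 3-ethylphenyl, 4-(trifluoromethyl)phenyl and 3,4-dichlorophenyl, now lie within the scatter of one another, and a ring carrying two chlorine atoms behaves no differently on these numbers from one carrying fluorine in a trifluoromethyl group or an ethyl group. Nothing available explains this flatness or says what the assay responds to at this position.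

Still open, from the compounds shown here alone, is whether any group on this nitrogen can move the number beyond the scatter, since all three compounds carry a six-membered aromatic ring of carbon only with no hydrogen-bond donors or acceptors on it, and an aryl bearing an amine or a carboxylic acid, or a longer chain in place of the aryl, would test that. Also open, going by these compounds, is what an exchange elsewhere on the shared core would do, as that part is the same in all three compounds.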